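The source may report more compounds than this note shows. Statements on the series, on what has been measured and on what is new or still open speak of the compounds shown alone.

Compound 1 `Cn1c(-c2ccc([N+](=O)[O-])cc2)nc2cc(C(F)(F)F)ccc21` gives > 100000 nM in an ADME assay on MDBK cells (Bos taurus) for cytotoxicity, read by MTT assay, with a stated time of 96 h (a lower number here means that less compound is tolerated, a higher number that more compound is tolerated), which is a limit of the assay rather than a number.
Compound 2 `CN1CCN(CC(=O)Nc2ccc(-c3nc4cc(C(F)(F)F)ccc4n3C)cc2)CC1` gives 44000 nM.

Going by the values given here, compound 2 therefore holds the only actual number in this assay , the other result being a limit, as the limit of > 100000 nM in this assay, at which 1 of the 2 values shown sits, states. Compound 3 `Cn1c(-c2ccc(NC(=O)CN3CCCC3)cc2)nc2cc(C(F)(F)F)ccc21` is not yet measured. It differs from compound 2 by pyrrolidin-1-yl in place of 4-methylpiperazin-1-yl on a saturated chain carbon bound to a carbonyl carbon. Among the compounds with values here, no measured pair shows a step of this kind, so the expected step from compound 2 to compound 3 is a 1.3-fold lower number from compound 2 to compound 3 (0.10 log units; within the scatter), hardly beyond the usual scatter in either direction. On that basis compound 3 is estimated at 35000 nM, within a range from 15000 nM to 90000 nM.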

Compound 3, half-maximal cytotoxic concentration: 65000 nM
For compound 3 the middle estimate is 1.9-fold (0.27 log units) below the measured one; measured number inside the range.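

In this assay, the exchange on a saturated chain carbon bound to a carbonyl carbon gives a 1.5-fold higher number from compound 2 to compound 3 (0.17 log units; within the scatter), so the two rings cannot be told apart here. Putting (((pyrrolidin-1-yl)methyl)carbonyl)amino in place of nitro on an aromatic carbon gives an at least 1.5-fold lower number from compound 1 to compound 3 (0.18 log units; that floor lies within the scatter), so this larger exchange shows no clear difference either. The result for compound 1 is a limit and not a number: the limit of > 100000 nM in this assay, at which 1 of the 3 values shown sits.

Still open, going by these compounds, is how an open-chain amine such as dimethylamino, or a morpholine ring, would read at the same place. A longer chain before the amine also remains untested among the compounds shown.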